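Swapping the aryl group on the fused core

The compounds below may be only part of what the source reports. "The series", "measured", "known", "first", "only" and "open" are said of these compounds alone.

Measured compounds:
compound 1 `O=S(=O)(Nc1ccc(F)c(C#Cc2cnc3[nH]ncc3c2)c1F)c1cccnc1`, 445 nM
compound 2 `O=S(=O)(Nc1ccc(F)c(C#Cc2cnc3[nH]nc(C4CC4)c3c2)c1F)c1cccnc1`, 61 nM
compound 3 `O=S(=O)(Nc1ccc(F)c(C#Cc2cnc3[nH]nc(-c4ccccc4Cl)c3c2)c1F)c1cccnc1`, 3600 nM

In a functional assay on COLO 205 cells (Homo sapiens) for antiproliferative activity, read by MTT assay, with a stated time of 68 h (a lower number here means a stronger inhibitor, a higher number a weaker inhibitor), compound 3 gives the highest number of the three, so it is the weakest inhibitor here. From it, compound 4 `O=S(=O)(Nc1ccc(F)c(C#Cc2cnc3[nH]nc(-c4ccc(F)cc4)c3c2)c1F)c1cccnc1` arises by one change: 4-fluorophenyl in place of 2-chlorophenyl on an aromatic carbon. Among the measured compounds shown here, no measured step exchanges one aryl group for another; the steps that bear on this position are a 7.3-fold lower number from compound 1 to compound 2 (0.86 log units; beyond the scatter) and an 8.1-fold higher number from compound 1 to compound 3 (0.91 log units; beyond the scatter), showing that a substituent on this carbon can move the number strongly either way. Since compound 4 keeps an aryl group at the same place, its number is expected near that of compound 3, with a modest improvement possible: the estimate is a 2.4-fold lower number from compound 3 to compound 4 (0.38 log units; beyond the scatter), giving 1500 nM with a range of 300 nM to 8000 nM.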

Compound 4, half-maximal inhibitory concentration: 166 nM
Estimate against measurement, compound 4: 9.0-fold (0.96 log units) above; measured number outside the range, below it.
By their numbers in this assay, from the lowest: compound 2; then compound 4; then compound 1; then compound 3.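

In this assay an aryl group on this carbon need not weaken the compound: the swap gives a 22-fold lower number from compound 3 to compound 4 (1.34 log units; beyond the scatter) and so shows that the choice of aryl group matters, not just its presence. Against the unsubstituted core, 4-fluorophenyl gives a 2.7-fold lower number from compound 1 to compound 4 (0.43 log units; beyond the scatter) but still falls short of cyclopropyl, with a 2.7-fold higher number from compound 2 to compound 4 (0.43 log units; beyond the scatter) in the other direction. Nothing available explains the gap between the two aryl groups.

Compounds 3 and 4 differ in both the halogen and its place on the ring, so these two changes cannot be separated. From the compounds shown here alone, how plain phenyl or an amine-bearing phenyl would behave here remains open.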